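Amino for Nitro on Two Related Anilide Cores

The source may report more compounds than this note shows. Statements on the series, on what has been measured and on what is new or still open speak of the compounds shown alone.

The study concerns a small set of trimethoxybenzamide-type anilides tested in a functional assay on HT-29 cells (Homo sapiens) for antiproliferative activity, read by MTT assay, with a stated time of 72 h; a lower number here means a stronger inhibitor, a higher number a weaker inhibitor. Compound 1 `COc1ccc(NC(=O)c2cc(OC)c(OC)c(OC)c2)cc1[N+](=O)[O-]` gives 9700 nM in this assay. Compound 2 `COc1ccc(NC(=O)c2cc(OC)c(OC)c(OC)c2)cc1N` carries amino in place of nitro on an aromatic carbon and gives 1200 nM in this assay, so that an 8.1-fold lower number from compound 1 to compound 2 (0.91 log units; beyond the scatter). Compound 3 `COc1ccc(C(=O)Nc2cc(OC)c(OC)c(OC)c2)cc1[N+](=O)[O-]` has the same atoms as compound 1 joined differently; the difference between the two cores is not broken down here. In this assay compound 3 gives 8300 nM, which lies within the scatter of the value of compound 1. Compound 4 `COc1ccc(C(=O)Nc2cc(OC)c(OC)c(OC)c2)cc1N` is the still unmeasured counterpart of compound 3 and bears the same change that separates compound 2 from compound 1 (amino in place of nitro on an aromatic carbon). Because compound 1 is matched by compound 3 at 8300 nM, and the change has already produced an 8.1-fold lower number from compound 1 to compound 2 (0.91 log units; beyond the scatter), the author expects a step of similar size, a 6.9-fold lower number from compound 3 to compound 4 (0.84 log units; beyond the scatter), in this assay. Compound 4 is therefore estimated at 1200 nM in this assay, with a plausible range from 400 nM to 4000 nM.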

Compound 4, half-maximal inhibitory concentration: > 100000 nM
Compound 4: a limit, no number; the forecaster's own chance of this, stated with the estimate: 3%; middle value at least 83-fold (1.92 log units) away from the limit.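

Compound 4 stands at a limit of the assay, not at a number, in this assay: the limit of > 100000 nM in this assay, at which 1 of the 4 values shown sits. Amino in place of nitro on an aromatic carbon gives an at least 12-fold higher number from compound 3 to compound 4 (1.08 log units; beyond the scatter), so the change does not carry over from one core to the other, and its direction is reversed: the same change on two cores in this assay, an 8.1-fold lower number (0.91 log units; beyond the scatter) from compound 1 to compound 2 and an at least 12-fold higher number (1.08 log units; beyond the scatter) from compound 3 to compound 4, at least 97-fold (1.98 log units) apart, beyond the scatter of two such steps. Among these compounds, this shows that the result of the change on the core of compound 1 cannot be transferred to the core of compound 3, but with only one pair on each core it does not show which difference between the cores is responsible, nor does it give a rule for the wider series.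

The compounds shown leave open how other groups on the same aromatic carbon, such as a hydroxyl, an acetamide or a methylamino group, would behave on each core. They also leave open whether a methyl group on the amide nitrogen would alter the contrast between the two cores.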